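Removing a Methyl from an Amine on Two Cores

The source may report more compounds than this note shows. Statements on the series, on what has been measured and on what is new or still open speak of the compounds shown alone.

Compound 1, `CN(C)c1ccc(/C=C/c2c(F)cccc2Cl)cc1`, gives 19.2 nM in a functional assay on LS174T cells (Homo sapiens) for antiproliferative activity; on this read-out lower numbers stand for stronger inhibition and higher numbers for weaker inhibition.
Compound 2, `CNc1ccc(/C=C/c2c(F)cccc2Cl)cc1`, gives 7.6 nM in this assay.
Compound 3, `CN(C)c1ccc(/C=C/c2c(F)cccc2Cl)cn1`, gives 4.7 nM in this assay.

Compound 2 differs from compound 1 by hydrogen in place of methyl on a nitrogen on an aromatic ring, and this change produced a 2.5-fold lower number from compound 1 to compound 2 (0.40 log units; beyond the scatter). Compound 3 carries a different core; the difference between the two cores is not broken down here. Compound 3 shows the lowest number of the three, though its gap to compound 2 lies within the scatter. Compound 4, `CNc1ccc(/C=C/c2c(F)cccc2Cl)cn1`, has not yet been measured in this assay. It differs from compound 3 by hydrogen in place of methyl on a nitrogen on an aromatic ring, the same change at the same kind of place. Because the step of a 2.5-fold lower number from compound 1 to compound 2 (0.40 log units; beyond the scatter) was modest but beyond the scatter, a similar fall is expected here, giving an estimated 1.9-fold lower number from compound 3 to compound 4 (0.27 log units; within the scatter). Compound 4 is therefore expected to give about 2.5 nM, with a likely range from 1.2 nM to 6 nM.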

Compound 4, half-maximal inhibitory concentration: 4 nM
Compound 4: middle estimate off by 1.6-fold (0.20 log units), on the low side; measured number inside the range.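

On the core of compound 3, putting hydrogen in place of methyl on the nitrogen gave a 1.2-fold lower number from compound 3 to compound 4 (0.07 log units; within the scatter), so on this core the change cannot be told apart from the ordinary spread of repeated measurements. Set beside the earlier step, the new one does not differ from it by more than that spread allows: the same change on two cores in this assay, a 2.5-fold lower number (0.40 log units; beyond the scatter) from compound 1 to compound 2 and a 1.2-fold lower number (0.07 log units; within the scatter) from compound 3 to compound 4, 2.2-fold (0.33 log units) apart, within the scatter of two such steps. This fits the change carrying over from one core to the other, but it does not prove that the effect is the same on both, nor that it depends on the core, and a single pair on each core cannot settle this. As far as these compounds go, it remains open how a free amine or a longer chain on this nitrogen would behave. From the compounds shown here alone, it also remains open whether such groups would give similar results on the two cores.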